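Bromo to Iodo: One More Halogen Step

This account rests on a few compounds, and the source may have more. Where it says the series, first, only, none or still open, it means among the compounds named here.

Across a functional assay on AGS cells (Homo sapiens) for inhibition, read by reporter gene assay (on this read-out lower numbers stand for stronger inhibition and higher numbers for weaker inhibition), three compounds sharing one core have been measured so far. Compound 1 `O=C(COc1ccccc1)Nc1cccc(C(=O)O)c1` gives > 30000 nM as a limit of the assay and not a number. Compound 2 `O=C(COc1ccc(Cl)cc1)Nc1cccc(C(=O)O)c1` gives 10000 nM as a true measured number. Compound 3 `O=C(COc1ccc(Br)cc1)Nc1cccc(C(=O)O)c1` gives 1600 nM and so holds the lowest number of the three, with compound 2 as its nearest neighbour.

Compound 4 `O=C(COc1ccc(I)cc1)Nc1cccc(C(=O)O)c1` has not yet been measured. It differs from compound 3 in one place: iodo in place of bromo on an aromatic carbon (iodo in place of bromo on an aromatic carbon, para to a large group).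

Earlier halogen changes bear on this. One gave an at least 3.0-fold lower number from compound 1 to compound 2 (0.47 log units; beyond the scatter) with chloro in place of hydrogen, at least modest in size. Another gave a 6.3-fold lower number from compound 2 to compound 3 (0.80 log units; beyond the scatter) with bromo in place of chloro, a modest step. Together they amount to an at least 18-fold lower number from compound 1 to compound 3 (1.27 log units; beyond the scatter) and form a large step overall. Among the compounds with values here, the number falls with each change and no compound here goes against that, though three compounds make a short series. A further but smaller fall is therefore expected in this assay for the iodo compound. The expected size is a 2.3-fold lower number from compound 3 to compound 4 (0.36 log units; beyond the scatter) by this estimate, only just beyond the usual scatter. For compound 4 the estimated value is 700 nM with an expected range from 200 nM to 2500 nM in all.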

Compound 4, half-maximal inhibitory concentration: 3500 nM
Compound 4: the middle estimate sits 5.0-fold (0.70 log units) below what was measured, and the stated range ends below it.
By their numbers in this assay, from the lowest: compound 3; then compound 4; then compound 2. At a limit, above all of these: compound 1.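

Within the data shown here, at this position, para to a large group, the run of falling numbers in this assay does not continue past bromo: iodo gives a 2.2-fold higher number from compound 3 to compound 4 (0.34 log units; beyond the scatter), and compound 4 is the one compound that goes against the earlier trend. Iodo still keeps part of the gain, with a 2.9-fold lower number from compound 2 to compound 4 (0.46 log units; beyond the scatter), so moving down the halogens does not simply lower the number, and bromo gives the lowest value among the four compounds. Compound 1 stands at a limit and not a number, so an at least 8.5-fold lower number from compound 1 to compound 4 (0.93 log units; beyond the scatter) gives only a minimum size for the gain from putting iodo in place of hydrogen: the limit of > 30000 nM in this assay, at which 1 of the 4 values shown sits.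

The four compounds show only how hydrogen, chloro, bromo and iodo compare at this one place, so they do not tell whether a non-halogen group such as methyl, trifluoromethyl, methoxy or an amine could match or beat bromo there. Also open, on these data alone, is whether fluoro would continue the halogen series at its light end, and whether the same order of halogens would hold at another place on the ring or with a change elsewhere in the shared core.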